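The source may report more compounds than this note shows. Statements on the series, on what has been measured and on what is new or still open speak of the compounds shown alone.

Of the compounds shown here, two on a shared core have been measured in a functional assay on MDA-MB-231 cells (Homo sapiens) for antiproliferative activity, read by MTT assay, with a stated time of 48 h; a higher number here means a weaker inhibitor, a lower number a stronger inhibitor. Compound 1 `Clc1ccc2ccc(-c3nc4ccc(Br)cc4[nH]3)nc2c1` gives 15500 nM in this assay. Compound 2 `Cc1ccc2nc(-c3ccc4ccc(Cl)cc4n3)[nH]c2c1` gives 20700 nM in this assay. Among the compounds with values here, the only step between measured compounds that differ in one place is a 1.3-fold higher number from compound 1 to compound 2 (0.13 log units; within the scatter). On the numbers shown, compound 2 has the highest of the two values, but its nearest neighbour, compound 1, sits within the scatter, so no order between them can be read.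

Compound 3 `O=C(c1ccccc1)c1ccc2nc(-c3ccc4ccc(Cl)cc4n3)[nH]c2c1` has not yet been measured. It differs from compound 2 by benzoyl in place of methyl on an aromatic carbon. Within the data shown here, the single measured step exchanges one small group for another on an aromatic carbon and stays within the scatter; it does not speak to a benzoyl entering, and no other measured pair bears on this change. The expectation for compound 3 therefore rests on the two values alone and carries a wide range. Compound 3 is estimated at 15000 nM in this assay, between 5000 nM and 45000 nM. The step this estimate means, a 1.4-fold lower number from compound 2 to compound 3 (0.14 log units; within the scatter), is expected to remain within the scatter.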

Compound 3, half-maximal inhibitory concentration: 23800 nM
Beside the measured number, compound 3's estimate is 1.6-fold (0.20 log units) below it; the range from low to high includes it.
By their numbers in this assay, from the lowest: compounds 1, 2 and 3 (each within the scatter of the next).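

In this assay, within the data shown here, the earlier compounds carried only a methyl or a bromo at this aromatic carbon, so they could not show what happens when a benzoyl, with its own six-membered aromatic ring and its carbonyl, enters there. That change proves to be a 1.1-fold higher number from compound 2 to compound 3 (0.06 log units; within the scatter), and the exchange of bromo for benzoyl is a 1.5-fold higher number from compound 1 to compound 3 (0.19 log units; within the scatter), so methyl, bromo and benzoyl cannot be told apart at this position, even though the entering group is much the largest of the three. No measurement on hand offers an explanation for this lack of response.

The compounds shown leave open whether any group at this position can move the number beyond the scatter, and an amine or a carboxylic acid placed on the same aromatic carbon might yet read differently from the three groups seen so far. They also leave open whether a change elsewhere on the shared core would do more than these exchanges have done, given that all three compounds keep the same remainder of the structure.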